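A few compounds are considered here, and "the series" means these few. Any claim that something is new, unique, unknown or untested is made for them only; others in the source may bear on it.

Measured in a physicochemical assay for lipophilicity, in phosphate buffer, measured as octanol-water partition, with a stated time of 24 h; on this read-out higher numbers stand for higher lipophilicity and lower numbers for lower lipophilicity:

Compound 1 `O=C(CSc1nc2ccccc2s1)N/N=C/c1ccc(Oc2ccc(Cl)cc2)cc1` gives 5.6.
Compound 2 `O=[N+]([O-])c1ccc(Oc2ccc(/C=N/Nc3nc4ccccc4s3)cc2)cc1` gives 5.1.
Compound 3 `Cc1cc(Oc2ccc(/C=N/Nc3nc4ccccc4s3)cc2)ccc1Cl` gives 5.5.

Among these three numbers compound 3 stands second highest. Its nearest neighbour is compound 1, whose value lies higher by an amount within the usual scatter, so the two cannot be told apart. Among the compounds with values here, the only clear separation is to compound 2: the step of a number 0.40 log units higher from compound 2 to compound 3 (beyond the scatter) is the one measured step in this set, and it comes from exchanging a whole aryl group on the oxygen.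

Compound 4 `Clc1ccc(Oc2ccc(/C=N/Nc3nc4ccccc4s3)cc2)cc1` is reached from compound 3 by a much smaller change: hydrogen in place of methyl on an aromatic carbon. Within the data shown here, no measured step covers the loss of a methyl alone; the step from compound 2 to compound 3 involved a different swap and so gives only a loose guide. Losing one carbon from an aromatic ring is generally a small move on this assay, and compound 4 is therefore expected to sit somewhat lower than compound 3, with the expected step being a number 0.50 log units lower from compound 3 to compound 4 (beyond the scatter). The estimate for compound 4 is 5, within a range from 4.6 to 5.4.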

Compound 4, partition coefficient: 5.6
Compound 4: middle estimate off by 0.60 log units, on the low side; the whole stated range lies below it.
By their numbers in this assay, from the lowest: compound 2; then compounds 3, 1 and 4 (each within the scatter of the next).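

In this assay, hydrogen in place of methyl on the aromatic carbon ortho to the chloro group gives a number 0.10 log units higher from compound 3 to compound 4 (within the scatter), so compound 3 and compound 4 cannot be told apart and this methyl leaves no measurable mark on the read-out. The earlier step from compound 2 changed two things at once, whereas chloro in place of nitro alone gives a number 0.50 log units higher from compound 2 to compound 4 (beyond the scatter), a clear separation that needs no methyl at all. No independent measurement here accounts for either result.

On these data alone, it remains open whether a larger group on that same carbon, such as an ethyl or a methoxy group, would also go unnoticed on this read-out. As far as these compounds go, it is also open how an amine or a carboxylic acid in place of the chloro would compare.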